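Chain-end swap: chloro replaces methoxymethoxy on the oxazole series

The source may report more compounds than this note shows. Statements on the series, on what has been measured and on what is new or still open speak of the compounds shown alone.

Measured so far in an assay for inhibition of Fatty-acid amide hydrolase 1 (Rattus norvegicus), using a Dixon plot; a lower number here means a stronger inhibitor, a higher number a weaker inhibitor:
compound 1 `O=C(CCCCCCc1ccccc1)c1ncc(-c2ccc(CCl)cn2)o1` gives 22.4 nM
compound 2 `COC(=O)CCCCc1cnc(C(=O)CCCCCCc2ccccc2)o1` gives 1.8 nM
compound 3 `COCOCCCCCc1cnc(C(=O)CCCCCCc2ccccc2)o1` gives 24.1 nM

Compound 3 has the highest number of the three, though its gap to compound 1 is within the scatter, as a 1.1-fold higher number from compound 1 to compound 3 (0.03 log units; within the scatter) shows. Its gap to compound 2 is another matter: a 13-fold higher number from compound 2 to compound 3 (1.13 log units; beyond the scatter) is a large step, so the group at the end of the chain clearly matters in this assay.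

Compound 4 `O=C(CCCCCCc1ccccc1)c1ncc(CCCCCCl)o1` differs from compound 3 by chloro in place of methoxymethoxy on a saturated chain carbon, five bonds along the chain from an aromatic carbon. Going by the values given here, no measured step trades an oxygen-bearing chain end for a halogen on an otherwise unchanged chain, so the closest guidance is indirect: the large step from compound 2 to compound 3 says the chain end can move the number by a lot, while the step from compound 1 to compound 3 shows that two quite different ends can land in the same place. A modest change is therefore expected, most likely a small lowering, as a 1.6-fold lower number from compound 3 to compound 4 (0.21 log units; within the scatter). For compound 4 the estimate is 15 nM, with a range from 4 nM to 60 nM.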

Compound 4, inhibition constant: 5.2 nM
For compound 4 the middle estimate is 2.9-fold (0.46 log units) above the measured one; the measured number falls inside the stated range.
By their numbers in this assay, from the lowest: compound 2; then compound 4; then compounds 1 and 3 (each within the scatter of the next).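

In this assay, a chain end that carries no hydrogen-bond acceptors at this place, five bonds along the chain from an aromatic carbon, clearly outperforms methoxymethoxy (a 4.6-fold lower number from compound 3 to compound 4 (0.67 log units; beyond the scatter)), so the two oxygen-bearing ends do not sit together as a group: one is well ahead of chloro, the other well behind it. Chloro still falls short of the methoxycarbonyl end (a 2.9-fold higher number from compound 2 to compound 4 (0.46 log units; beyond the scatter)), yet it does better than the ring-bearing group of compound 1 (a 4.3-fold lower number from compound 1 to compound 4 (0.63 log units; beyond the scatter)), which places compound 4 clearly between the others. No separate measurement is available to explain these differences.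

The compounds shown leave open whether an amine or a carboxylic acid at this chain end would match compound 2. They also leave open whether bromo, or chloro on a longer chain, would keep the gain seen with compound 4.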